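A Fluorobenzyl Group on a Weak Toxicity Read-Out

This account rests on a few compounds, and the source may have more. Where it says the series, first, only, none or still open, it means among the compounds named here.

In a toxicity assay on GES1 cells (Homo sapiens) for inhibition, read by MTT assay, with a stated time of 72 h (on this read-out lower numbers stand for stronger inhibition and higher numbers for weaker inhibition), compound 1 `Cc1cc(N2CC[C@@H](C)[C@@H](N(C)c3ncnc4[nH]ccc34)C2)n2nc(SCc3ccccc3)nc2n1` gives 67200 nM and compound 2 `Cc1cc(N2CC[C@@H](C)[C@@H](N(C)c3ncnc4[nH]ccc34)C2)n2ncnc2n1` gives 57900 nM. For the measured compounds named here, compound 2 thus stands within the scatter of compound 1, the only other measured compound, and neither can be ranked above the other.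

The next compound, compound 3 `Cc1cc(N2CC[C@@H](C)[C@@H](N(C)c3ncnc4[nH]ccc34)C2)n2nc(SCc3ccc(F)cc3)nc2n1`, is reached from compound 2 by one structural change: (4-fluorobenzyl)sulfanyl in place of hydrogen on an aromatic carbon. In words, this is (4-fluorobenzyl)sulfanyl in place of hydrogen on an aromatic carbon, between two ring nitrogen atoms. Going by the values given here, the entering group is the benzylsulfanyl of compound 1 with fluorine added, and no measured compound shows what that fluorine does alone.

Among the compounds with values here, one measured step bears on the change, and it runs nearly in reverse: a 1.2-fold lower number from compound 1 to compound 2 (0.06 log units; within the scatter). Given the small size of that step, no shift beyond the scatter is expected in this assay. The expected step is a 1.1-fold higher number from compound 2 to compound 3 (0.05 log units; within the scatter).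

For compound 3 the estimated value is 65000 nM, with an expected range from 35000 nM to 110000 nM.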

Compound 3, half-maximal inhibitory concentration: 12300 nM
The estimate for compound 3 lay 5.3-fold (0.72 log units) above the measured number, and the stated range ends above it.
By their numbers in this assay, from the lowest: compound 3; then compounds 2 and 1 (each within the scatter of the next).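

In this assay this aromatic carbon, between two ring nitrogen atoms, no longer looks indifferent to what it carries: (4-fluorobenzyl)sulfanyl in place of hydrogen gives a 4.7-fold lower number from compound 2 to compound 3 (0.67 log units; beyond the scatter), whereas the earlier pair showed only a 1.2-fold lower number from compound 1 to compound 2 (0.06 log units; within the scatter) on exchanging benzylsulfanyl and hydrogen. The comparison of the two sulfanyl groups isolates the fluorine, with fluoro in place of hydrogen on an aromatic carbon giving a 5.5-fold lower number from compound 1 to compound 3 (0.74 log units; beyond the scatter), so the step from the hydrogen compound appears only when the entering group carries fluorine. This holds for these three compounds only, and the size of both new steps is modest, although both lie beyond the scatter. For the compounds shown here, nothing available explains why the single fluorine changes the read-out in this way.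

The compounds shown leave open whether this step is particular to fluorine, since a chloro or methoxy group in its place on the benzyl group would be needed to tell. They also leave open whether an amine or a longer alkyl chain on the sulfur-bearing carbon would shift the number at all.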